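Sulfonyl piperidine amides: trimming the amide substituent

A few compounds are considered here, and "the series" means these few. Any claim that something is new, unique, unknown or untested is made for them only; others in the source may bear on it.

Measured so far:
- compound 1 `CCOC(=O)[C@@H]1CCCN(S(=N)(=O)c2ccc(S(=O)(=O)N(CC)CC)cc2)C1` — 12100 nM
- compound 2 `CCN(CC)S(=O)(=O)c1ccc(S(=O)(=O)N2CCC[C@@H](C(=O)N[C@@H]3CCN(C(=O)OC(C)(C)C)C3)C2)cc1` — 200 nM
- compound 3 `CCOC(=O)[C@@H]1C[C@@H](O)CN(S(=O)(=O)c2ccc(S(=O)(=O)N(CC)CC)cc2)C1` — 7900 nM

In a functional assay on MIA PaCa-2 cells (Homo sapiens) for inhibition, read by MTT assay, with a stated time of 7 days (on this read-out lower numbers stand for stronger inhibition and higher numbers for weaker inhibition), compound 2 gives 200 nM, the lowest number of the three. Compound 3, the nearest, gives 7900 nM, and compound 1 gives 12100 nM; both gaps to compound 2 lie well beyond the scatter, so compound 2 is the most potent of the set. Within the data shown here, compounds 1 and 3 carry an ethyl ester where compound 2 carries the amide; no single-point step between them is available.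

Compound 4 `CCN(CC)S(=O)(=O)c1ccc(S(=O)(=O)N2CCC[C@@H](C(=O)NC)C2)cc1` is the next point. It differs from compound 2 by methyl in place of 1-(tert-butoxycarbonyl)pyrrolidin-3-yl on an amide-type nitrogen. The change removes most of the amide-side bulk of compound 2, and the only comparators with a small group at that end are the esters.

Compound 4 is expected to lose potency relative to compound 2 because compound 1 gives 12100 nM and compound 3 gives 7900 nM, both with small groups at the same end of the shared core. The estimated step is a 15-fold higher number from compound 2 to compound 4 (1.18 log units; beyond the scatter), beyond the scatter. Compound 4 is estimated at 3000 nM, with a range of 600 nM to 15000 nM.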

Compound 4, half-maximal inhibitory concentration: 8600 nM
For compound 4 the middle estimate is 2.9-fold (0.46 log units) below the measured one; the range from low to high includes it.
By their numbers in this assay, from the lowest: compound 2; then compounds 3, 4 and 1 (each within the scatter of the next).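

In this assay, among these compounds, the single change of methyl in place of 1-(tert-butoxycarbonyl)pyrrolidin-3-yl on the amide-type nitrogen gives a 43-fold higher number from compound 2 to compound 4 (1.63 log units; beyond the scatter), the first step that can be read at one place. The substituent on this nitrogen therefore has a large effect on the read-out, and the amide link, present in both compounds, does not by itself give the low number of compound 2 (200 nM). Nothing measured here accounts for the size of this step.

The step removes 12 heavy atoms at once, including a ring, a carbamate and a defined stereocentre, so the pair cannot assign the difference to any one part of the departing group. Going by these compounds, it remains open whether a free pyrrolidin-3-yl amine without the tert-butoxycarbonyl group, a cyclopentyl ring with no nitrogen, or a longer chain such as n-butyl on the same amide nitrogen would stay close to compound 2 or to compound 4.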